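The source may report more compounds than this note shows. Statements on the series, on what has been measured and on what is new or still open speak of the compounds shown alone.

Measured compounds:
- compound 1, `COc1ccc(Br)cc1CCc1c(F)cccc1C(=O)/N=C(\N)NCCN1CCCC1`: 4500 nM
- compound 2, `COc1ccc(Br)cc1CCc1c(F)cccc1C(=O)/N=C(\N)NCCC1CCCCC1`: "not determined" (no result reported)
- compound 3, `COc1ccc(Br)cc1CCc1c(F)cccc1C(=O)/N=C(\N)NCCCCN(C)Cc1ccccc1`: 180 nM

In a functional assay for antagonist activity at Melanocortin receptor 4 (Homo sapiens), read by cAMP accumulation (a lower number here means a stronger inhibitor, a higher number a weaker inhibitor), compound 3 gives the lowest of the two numbers reported; compound 2 has no number. Going by the values given here, its nearest neighbour is compound 1, and the step of a 25-fold lower number from compound 1 to compound 3 (1.40 log units; beyond the scatter) is the only measured change, reached by putting an open-chain benzyl(methyl)amino tail in place of a ring amine.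

Compound 4, `COc1ccc(Br)cc1CCc1c(F)cccc1C(=O)/N=C(\N)NCCCN1CCN(C)CC1`, reverses that kind of change: 4-methylpiperazin-1-yl in place of (benzyl(methyl)amino)methyl on a saturated chain carbon, three bonds along the chain from an amine nitrogen. The tail goes back from an open-chain benzyl(methyl)amino group to a ring amine, so the step of a 25-fold lower number from compound 1 to compound 3 (1.40 log units; beyond the scatter) is the one that bears on it, and it was large. Compound 4 is therefore expected to move back toward compound 1, though the ring here is a methylpiperazine rather than a pyrrolidine and the chain differs, so the return is expected to be partial: an 8.3-fold higher number from compound 3 to compound 4 (0.92 log units; beyond the scatter), toward a higher number. For compound 4 the estimate in this assay is 1500 nM, with a range from 300 nM to 6000 nM.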

Compound 4, half-maximal inhibitory concentration: 670 nM
The estimate for compound 4 lay 2.2-fold (0.35 log units) above the measured number; the range from low to high includes it.
By their numbers in this assay, from the lowest: compound 3; then compound 4; then compound 1.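

In this assay a ring amine on the tail does not by itself bring the number back to that of compound 1: 4-methylpiperazin-1-yl in place of (benzyl(methyl)amino)methyl gives a 3.7-fold higher number from compound 3 to compound 4 (0.57 log units; beyond the scatter), smaller than the step the open-chain tail gave over pyrrolidin-1-yl. (4-Methylpiperazin-1-yl)methyl in place of pyrrolidin-1-yl still gives a 6.7-fold lower number from compound 1 to compound 4 (0.83 log units; beyond the scatter), so the six-membered aromatic ring of the benzyl group is not needed for a number well under that of compound 1. No measurement at hand accounts for these differences.

Ring and chain change together between compound 1 and compound 4, so their separate shares remain open. A 3-(pyrrolidin-1-yl)propyl tail would isolate the chain, and a 4-benzylpiperazin-1-yl tail would show whether the benzyl group adds to the piperazine ring.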